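The source may report more compounds than this note shows. Statements on the series, on what has been measured and on what is new or still open speak of the compounds shown alone.

For the measured compounds named here, compound 2 `CNc1nc(NCc2ccc(Cl)cc2)cc(-c2ccccn2)n1` is the stronger of the two compounds measured so far. In a functional assay on HEK293 cells for agonist activity at G-protein coupled receptor 39 (Mus musculus), read by inositol phosphate accumulation (a lower number here means that less compound is needed, a higher number that more compound is needed for the effect), compound 2 gives 3 nM, which is the lowest of the two numbers. Its neighbour, compound 1 `CNc1nc(NCC(C)(C)C)cc(-c2ccccn2)n1`, carries a tert-butyl group where compound 2 carries a 4-chlorophenyl group, and in this assay compound 1 gives 365 nM. That single change produced a 120-fold lower number from compound 1 to compound 2 (2.09 log units; beyond the scatter), a large step.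

Compound 3 `CNC(=O)c1ccc(CNc2cc(-c3ccccn3)nc(NC)n2)cc1` is not yet measured. It differs from compound 2 in one place: methylcarbamoyl in place of chloro on an aromatic carbon. Going by the values given here, the change therefore sits on the ring that was itself introduced in the step from compound 1 to compound 2, and no measured step alters this ring position, so the only step on record, large as it was, does not bear directly on it. With nothing to anchor the direction, a step of moderate size either way is as plausible as none beyond the scatter. For compound 3 the expected result in this assay is 12 nM, with a range from 2 nM to 70 nM. This expectation corresponds to a 4.0-fold higher number from compound 2 to compound 3 (0.60 log units; beyond the scatter).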

Compound 3, half-maximal effective concentration: 8 nM
Estimate against measurement, compound 3: 1.5-fold (0.18 log units) above; low and high end bracket the measured number.
By their numbers in this assay, from the lowest: compound 2; then compound 3; then compound 1.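

Replacing chloro with methylcarbamoyl on this aromatic carbon, para to a large group, gives in this assay a 2.7-fold higher number from compound 2 to compound 3 (0.43 log units; beyond the scatter), a modest step compared with the large one that brought the 4-chlorophenyl group in. The position therefore accepts an entering group of 4 heavy atoms, with 1 hydrogen-bond donor and 1 hydrogen-bond acceptor, in place of a single chlorine, and compound 3 still gives 8 nM. No measurement at hand explains why the number rises with this change.

A single exchange swaps the chlorine for a larger group and adds the donor and acceptor all at once, so the compounds shown cannot say which of these differences accounts for the step. Other groups at this position, such as a carboxylic acid, a dimethylcarbamoyl group lacking the amide hydrogen, or a simple methyl group, would be needed to tell how far this tolerance extends and whether the amide itself matters.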